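The compounds below may be only part of what the source reports. "The series", "measured", "known", "first", "only" and "open" are said of these compounds alone.

Measured in a functional assay on L1210 cells (Mus musculus) for cytotoxicity; a higher number here means that more compound is needed for the effect, a lower number that less compound is needed:
compound 1, `COc1cc(C(C)O)c(OC)c2c1C(=O)C=CC2=O`, 0.132 ug/mL
compound 2, `CCCCCCCC(O)c1cc(OC)c2c(c1OC)C(=O)C=CC2=O`, 0.274 ug/mL
compound 3, `CCCCCCCC(O)C1=CC(=O)c2c(OC)ccc(OC)c2C1=O`, 1.04 ug/mL

Compounds 2 and 3 share the same atoms joined differently; the difference between the two cores is not broken down here. Compound 3 stands highest of the three, and compound 1 lowest.

From compound 2 to compound 1 the change is hydrogen in place of hexyl on a saturated chain carbon, two bonds along the chain from an aromatic carbon and an oxygen on a saturated carbon, and the step it made was a 2.1-fold lower number from compound 2 to compound 1 (0.32 log units; beyond the scatter). Compound 4, `COc1ccc(OC)c2c1C(=O)C=C(C(C)O)C2=O`, is not yet measured. It differs from compound 3 by hydrogen in place of hexyl on a saturated chain carbon, two bonds along the chain from a double-bonded ring carbon and an oxygen on a saturated carbon. Around the place, the saturated chain carbon sits two bonds from a double-bonded ring carbon rather than from an aromatic carbon, so this is the same kind of change, not the same one. Because the earlier pair gave a 2.1-fold lower number from compound 2 to compound 1 (0.32 log units; beyond the scatter), a step of similar size is expected here, a 2.1-fold lower number from compound 3 to compound 4 (0.32 log units; beyond the scatter). For compound 4 a value of about 0.5 ug/mL is estimated, between 0.22 ug/mL and 1.2 ug/mL.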

Compound 4, concentration for half-maximal effect: 0.487 ug/mL
Beside the measured number, compound 4's estimate is 1.0-fold (0.01 log units) above it; low and high end bracket the measured number.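

In this assay, hydrogen in place of hexyl gave a 2.1-fold lower number from compound 3 to compound 4 (0.33 log units; beyond the scatter), and the two cores responded alike: the same change on two cores in this assay, a 2.1-fold lower number (0.32 log units; beyond the scatter) from compound 2 to compound 1 and a 2.1-fold lower number (0.33 log units; beyond the scatter) from compound 3 to compound 4, 1.0-fold (0.01 log units) apart, within the scatter of two such steps The change therefore carried over with its size intact, even though the saturated chain carbon sits two bonds from a double-bonded ring carbon in one pair and from an aromatic carbon in the other. For the compounds shown here, this rests on only two pairs, however, and it shows neither why the number falls nor whether the step would hold on any further core.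

The compounds shown have only hexyl or hydrogen at this place. From the compounds shown here alone, how a shorter or longer chain would behave there remains open, as does the effect of an amine or a carboxylic acid at the chain end.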